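This account rests on a few compounds, and the source may have more. Where it says the series, first, only, none or still open, it means among the compounds named here.

Compound 1 `N#CN/C(=N\CCCCCCOc1ccccc1)Nc1cccnc1` gives 52 nM
Compound 2 `N#CN/C(=N\CCCCCCCOc1ccccc1)Nc1cccnc1` gives 22 nM
Compound 3 `COc1ccccc1OCCCCCC/N=C(\NC#N)Nc1ccncc1` gives 0.5 nM

In a functional assay on NSCLC cells (Homo sapiens) for antiproliferative activity (on this read-out higher numbers stand for weaker inhibition and lower numbers for stronger inhibition), compound 3 has the lowest number of the three at 0.5 nM so it is the reference point here. The next compound is compound 4 `COc1ccc(OCCCCCC/N=C(\NC#N)Nc2ccncc2)cc1` with the change 4-methoxyphenyl in place of 2-methoxyphenyl on an oxygen on a saturated carbon in which 4-methoxyphenyl stands in place of 2-methoxyphenyl on an oxygen on a saturated carbon. Going by the values given here, the only measured step is a 2.4-fold lower number from compound 1 to compound 2 (0.37 log units; beyond the scatter) and it changes the chain, not a methoxy group, so it bears only loosely. Among the compounds with values here, a moderate step toward a higher number is expected in this assay since compound 3 at 0.5 nM has the lowest number so far. The estimated step is a 3.0-fold higher number from compound 3 to compound 4 (0.48 log units; beyond the scatter) for now. Compound 4 is estimated at 1.5 nM with an expected range from 0.2 nM to 12 nM for this measurement.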

Compound 4, half-maximal inhibitory concentration: 12 nM
The estimate for compound 4 lay 8.0-fold (0.90 log units) below the measured number; the measured number falls inside the stated range.
By their numbers in this assay, from the lowest: compound 3; then compounds 4 and 2 (each within the scatter of the next); then compound 1.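

In this assay the two compounds have the same atoms, yet going from 2-methoxyphenoxy to 4-methoxyphenoxy gives a 24-fold higher number from compound 3 to compound 4 (1.38 log units; beyond the scatter) and so counts as a large change. Going by these compounds alone, the series is therefore sensitive to where the methoxy group sits, on a scale that the modest chain step between the earlier compounds did not show. Nothing measured here explains this difference.

Going by these compounds, whether ethoxy or fluorine in place of the methoxy group would keep the low number of compound 3 remains open. Also open, on these data alone, is whether the gap between the two methoxyphenoxy groups persists on a longer chain.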